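The source may hold more compounds than are shown below. What is called first, only, known or untested is meant among the compounds shown, and "the series" means these compounds.

For the measured compounds named here, compound 2 `CCCc1ccccc1N1CCN(CCCNc2ncccc2C(=O)N(C)C)CC1` gives 31.6 nM in a functional assay on aorta for antagonist activity at Alpha-1D adrenergic receptor (Rattus norvegicus) (on this read-out lower numbers stand for tighter binding and higher numbers for weaker binding), the higher of the two numbers so far, though the step of a 1.6-fold higher number from compound 1 to compound 2 (0.20 log units; within the scatter) is within the scatter. Going by the values given here, its only neighbour, compound 1 `COc1ccccc1N1CCN(CCCNc2ncccc2C(=O)N(C)C)CC1`, gives 20 nM. Compound 3 `COc1ccc(N2CCN(CCCNc3ncccc3C(=O)N(C)C)CC2)c(OC)c1` differs from compound 2 by 2,4-dimethoxyphenyl in place of 2-propylphenyl on an amine nitrogen in a ring. Among the compounds with values here, the one measured step bears on this only loosely, since it exchanged propyl and methoxy on an aromatic carbon and stayed within the scatter, so a move back toward methoxy-bearing rings is expected to change little. Compound 3 is therefore expected near 20 nM, within 8 nM to 50 nM. The expected step is a 1.6-fold lower number from compound 2 to compound 3 (0.20 log units; within the scatter).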

Compound 3, dissociation constant: 1000 nM
Estimate against measurement, compound 3: 50-fold (1.70 log units) below, and the stated range ends below it.
By their numbers in this assay, from the lowest: compounds 1 and 2 (each within the scatter of the next); then compound 3.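

In this assay the aromatic ring on the amine nitrogen proves sensitive to substitution: one added methoxy in place of hydrogen on an aromatic carbon gives a 50-fold higher number from compound 1 to compound 3 (1.70 log units; beyond the scatter) and the full exchange of 2-propylphenyl for 2,4-dimethoxyphenyl gives a 32-fold higher number from compound 2 to compound 3 (1.50 log units; beyond the scatter) as a large rise. The earlier exchange of propyl for methoxy, a 1.6-fold higher number from compound 1 to compound 2 (0.20 log units; within the scatter) by contrast, gave no sign of this. Nothing available here accounts for the rise. Going by these compounds, it remains open whether a fluorine or a hydroxyl at that aromatic carbon would give the same rise.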